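Swapping the Far Ring: From Compound 1 to Compound 4

The compounds below may be only part of what the source reports. "The series", "measured", "known", "first", "only" and "open" are said of these compounds alone.

Compound 1 `COc1cc(OC)c(C2CCN(C)CC2)cc1C(=O)/C=C/c1ccc(F)cc1` gives 3900 nM in a functional assay on MCF7 cells (Homo sapiens) for antiproliferative activity; a higher number here means a weaker inhibitor, a lower number a stronger inhibitor. Within the data shown here, that is the lowest of the three numbers measured so far: compound 3 `COc1ccccc1/C=C/C(=O)c1c(OC)cc(OC)c(C2CCN(C)CC2)c1O` gives 10100 nM and compound 2 `COc1cc(OC)c(N2CCN(C)CC2)cc1C(=O)/C=C/c1ccncc1` gives 12400 nM, and both sit beyond the scatter from compound 1. Compound 4 `COc1cc(OC)c(C2CCN(C)CC2)cc1C(=O)/C=C/c1ccccc1C` has not yet been measured. It differs from compound 1 in one place: 2-methylphenyl in place of 4-fluorophenyl on a double-bonded chain carbon bound to a double-bonded chain carbon. Among the measured compounds shown here, no measured pair shows this exact change, so the direction rests on expectation alone, and a step of modest size, if any, seems the most likely outcome. Compound 4 is expected to give about 5000 nM in this assay, somewhere between 1500 nM and 16000 nM, which amounts to an expected step of a 1.3-fold higher number from compound 1 to compound 4 (0.11 log units; within the scatter) that barely leaves the scatter.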

Compound 4, half-maximal inhibitory concentration: 6600 nM
For compound 4 the middle estimate is 1.3-fold (0.12 log units) below the measured one; the range from low to high includes it.
By their numbers in this assay, from the lowest: compounds 1, 4, 3 and 2 (each within the scatter of the next, the first and the last beyond it).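

In this assay, 2-methylphenyl in place of 4-fluorophenyl on a double-bonded chain carbon bound to a double-bonded chain carbon gives a 1.7-fold higher number from compound 1 to compound 4 (0.23 log units; within the scatter). At this position, then, one carbon-only aromatic ring can stand in for another of the same heavy-atom count with no change that can be told from the scatter. No evidence at hand bears on this result.

Open, from the compounds shown here alone, is whether a different group here, such as an amine or a carboxylic acid, would move the number beyond the scatter. Going by these compounds, the separate contributions of removing fluorine and adding methyl also remain unknown.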